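The compounds below may be only part of what the source reports. "The series", "measured", "known", "first", "only" and "open" are said of these compounds alone.

Compound 1, `O=C(/C=C/CNCCOc1ccc(Oc2c(-c3ccc(F)cc3)sc3cc(O)ccc23)cc1)N1CCCC1`, gives 11300 nM in a functional assay on Ishikawa cells (Homo sapiens) for antiproliferative activity, read by CCK-8 assay, with a stated time of 48 h; a higher number here means a weaker inhibitor, a lower number a stronger inhibitor.
Compound 2, `C=CC(=O)NCCOc1ccc(Oc2c(-c3ccc(F)cc3)sc3cc(O)ccc23)cc1`, gives > 25000 nM in this assay; this is a limit of the assay, not a measured number.

Compound 1 carries the only real number shown here; the other value is a limit, so no measured neighbour places it higher or lower. Compound 3, `CNC(=O)/C=C/CNCCOc1ccc(Oc2c(-c3ccc(F)cc3)sc3cc(O)ccc23)cc1`, differs from compound 1 in one place: methylamino in place of pyrrolidin-1-yl on a carbonyl carbon. Among the compounds with values here, the only measured step, an at least 2.2-fold higher number from compound 1 to compound 2 (0.34 log units; beyond the scatter), comes from a much larger rebuilding of the chain, so it bears on this change only loosely; what it does show is that a compound of this series can reach (the limit of > 25000 nM in this assay, at which 1 of the 2 values shown sits). The change from pyrrolidin-1-yl to methylamino leaves the chain and the carbonyl in place, and the step it brings in this assay is expected to be smaller than the step of an at least 2.2-fold higher number from compound 1 to compound 2 (0.34 log units; beyond the scatter). Compound 3 is therefore expected to give about 18000 nM, within 7000 nM to 45000 nM. This estimate means a 1.6-fold higher number from compound 1 to compound 3 (0.20 log units; within the scatter), an expected weakening that may well stay within the scatter.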

Compound 3, half-maximal inhibitory concentration: 15500 nM
Compound 3: middle estimate off by 1.2-fold (0.06 log units), on the high side, and the stated range covers the measured number.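

In this assay, replacing pyrrolidin-1-yl with methylamino on a carbonyl carbon gives a 1.4-fold higher number from compound 1 to compound 3 (0.14 log units; within the scatter), so the two compounds cannot be told apart here. This position therefore accepts the loss of the five-membered ring and a drop from 5 heavy atoms to 2, along with the gain of 1 hydrogen-bond donor, without a change that rises above the scatter. Compared with compound 2, the result is an at least 1.6-fold lower number from compound 2 to compound 3 (0.20 log units; that floor lies within the scatter), a floor that does not settle the order of the two compounds, and the value of compound 2 is only a limit: the limit of > 25000 nM in this assay, at which 1 of the 3 values shown sits.

Because methylamino differs from pyrrolidin-1-yl in both ring and amide hydrogen, these two compounds cannot separate those features, and a dimethylamino group on the same carbonyl carbon, with no ring and no amide hydrogen, would help to pull them apart. From the compounds shown here alone, it also remains open whether a larger group there, such as piperidin-1-yl or morpholin-4-yl, or a carboxylic acid in place of the amide, would move the number beyond the scatter.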